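Swapping an aryl ketone for a propanoyl on a pyrazoline nitrogen

The compounds below may be only part of what the source reports. "The series", "measured", "known", "first", "only" and "open" are said of these compounds alone.

Three pyrazoline derivatives have been tested in a functional assay on PC-3 cells (Homo sapiens) for cytotoxicity, read by MTT assay, with a stated time of 48 h; a higher number here means a weaker inhibitor, a lower number a stronger inhibitor. Compound 1, `CCC(=O)N1N=C(C)CC1c1cc(Br)ccc1O`, gives 37800 nM in this assay, and compound 2, `CC1=NN(C(=O)c2ccc(C)cc2)C(c2cc(Br)ccc2O)C1`, gives 41200 nM. These two share a core and differ only in that compound 1 carries ethyl in place of 4-methylphenyl on a carbonyl carbon; this change produced a 1.1-fold lower number from compound 2 to compound 1 (0.04 log units; within the scatter). Compound 3, `Cc1ccc(C(=O)N2N=C(c3cc4ccccc4oc3=O)CC2c2ccccc2)cc1`, gives 13200 nM, the lowest of the three numbers and beyond the scatter from both others. How the core of compound 3 differs from that of compound 2 is not broken down here.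

Compound 4, `CCC(=O)N1N=C(c2cc3ccccc3oc2=O)CC1c1ccccc1`, is not yet measured. It is derived from compound 3 by the same change seen between compound 2 and compound 1, namely (ethyl in place of 4-methylphenyl on a carbonyl carbon), and the surroundings of the carbonyl carbon are the same in both pairs. Within the data shown here, the estimated step is a 1.1-fold lower number from compound 3 to compound 4 (0.04 log units; within the scatter), because the one earlier instance of this change gave a 1.1-fold lower number from compound 2 to compound 1 (0.04 log units; within the scatter). Compound 4 is therefore expected to give about 12000 nM in this assay, plausibly between 5500 nM and 26000 nM.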

Compound 4, half-maximal inhibitory concentration: 4370 nM
Estimate against measurement, compound 4: 2.7-fold (0.44 log units) above, outside the stated range (below it).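

In this assay, putting ethyl in place of 4-methylphenyl on the carbonyl carbon gave a 3.0-fold lower number from compound 3 to compound 4 (0.48 log units; beyond the scatter), a real step on this core. The size of the step therefore did not carry over from one core to the other, and the earlier pair was a poor guide to this one: the same change on two cores in this assay, a 1.1-fold lower number (0.04 log units; within the scatter) from compound 2 to compound 1 and a 3.0-fold lower number (0.48 log units; beyond the scatter) from compound 3 to compound 4, 2.8-fold (0.44 log units) apart, beyond the scatter of two such steps. Among these compounds, with only two pairs, this shows that the result of the change depends on the core it is made on, but it does not show which part of the core matters, nor how a third core would respond.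

The compounds shown leave open whether the lower number on the core of compound 3 is specific to ethyl, or whether a longer chain such as butyl, or a chain ending in an amine or a carboxylic acid, on the same carbonyl carbon would do the same. They also leave open whether any such step on this core reflects more than cytotoxicity on this one cell line.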